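From Trifluoromethyl to Vinyl in a Small Series

This account rests on a few compounds, and the source may have more. Where it says the series, first, only, none or still open, it means among the compounds named here.

- compound 1 `COc1cc(-c2ccnc3cc(-c4c[nH]c5ccccc45)nn23)cc(OC)c1OC`: 35 nM
- compound 2 `COc1cc(-c2ccnc3cc(-c4ccc5cc[nH]c5c4)nn23)cc(OC)c1OC`: 187 nM
- compound 3 `COc1cc(-c2ccnc3cc(-c4ccc(C(F)(F)F)cc4)nn23)cc(OC)c1OC`: 1860 nM

In a functional assay on HCT-116 cells (Homo sapiens) for inhibition, read by CCK-8 assay, with a stated time of 48 h (on this read-out lower numbers stand for stronger inhibition and higher numbers for weaker inhibition), compound 3 gives 1860 nM, the highest of the three numbers. The closest measured neighbour is compound 2, as shown by the step of a 9.9-fold higher number from compound 2 to compound 3 (1.00 log units; beyond the scatter). The gap to compound 1 is wider, with a 53-fold higher number from compound 1 to compound 3 (1.73 log units; beyond the scatter). The two indolyl compounds also differ from each other, with a 5.3-fold higher number from compound 1 to compound 2 (0.73 log units; beyond the scatter).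

Compound 4 `C=Cc1ccc(-c2cc3nccc(-c4cc(OC)c(OC)c(OC)c4)n3n2)cc1` carries vinyl in place of trifluoromethyl on an aromatic carbon, para to a large group (vinyl in place of trifluoromethyl on an aromatic carbon). Within the data shown here, no measured step changes this group alone. The steps of a 9.9-fold higher number from compound 2 to compound 3 (1.00 log units; beyond the scatter) and a 53-fold higher number from compound 1 to compound 3 (1.73 log units; beyond the scatter) each exchange the whole 4-(trifluoromethyl)phenyl group, so they bear on this change only loosely. A much smaller step is therefore expected in this assay, leaning slightly towards a lower number and staying within the scatter. The estimated step is a 1.3-fold lower number from compound 3 to compound 4 (0.12 log units; within the scatter). Compound 4 is expected at 1400 nM, with an estimated range from 450 nM to 4000 nM.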

Compound 4, half-maximal inhibitory concentration: 1060 nM
Beside the measured number, compound 4's estimate is 1.3-fold (0.12 log units) above it, within the range that was stated.
By their numbers in this assay, from the lowest: compound 1; then compound 2; then compounds 4 and 3 (each within the scatter of the next).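

Among these compounds, compound 4 gives the first exchange confined to the small group itself, on an aromatic carbon para to a large group, and in this assay the step of a 1.8-fold lower number from compound 3 to compound 4 (0.24 log units; within the scatter) leaves trifluoromethyl and vinyl indistinguishable at this position. The wide gaps to the indolyl compounds persist with 4-vinylphenyl, as shown by a 5.7-fold higher number from compound 2 to compound 4 (0.75 log units; beyond the scatter) and by a 30-fold higher number from compound 1 to compound 4 (1.48 log units; beyond the scatter), so they are not peculiar to 4-(trifluoromethyl)phenyl. No supporting data explain why these two groups read alike here.

The compounds shown leave open whether an amine, a carboxylic acid or a longer chain such as propyl at this position would move the number beyond the scatter. They also leave open whether any such group on the phenyl ring could approach the indolyl compounds.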